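The compounds below may be only part of what the source reports. "The series", "measured", "known", "first", "only" and "open" are said of these compounds alone.

Working notes on the series. Compound 1 `CCc1ccc(-c2cc(C(=O)Nc3ccc(Oc4ccnc(C(=O)NC)c4)cc3)ncn2)cc1` gives 6350 nM in a functional assay on MCF7 cells (Homo sapiens) for cytotoxicity, read by MTT assay, with a stated time of 72 h; on this read-out lower numbers stand for stronger inhibition and higher numbers for weaker inhibition. Compound 2 `CCc1ccc(-c2cc(C(=O)Nc3ccc(Oc4ccnc(C(=O)NC)c4)c(F)c3)ncn2)cc1` gives 7630 nM in this assay. The step of a 1.2-fold lower number from compound 2 to compound 1 (0.08 log units; within the scatter) is hydrogen in place of fluoro on an aromatic carbon. Compound 3 `CNC(=O)c1cc(Oc2ccc(NC(=O)c3nccc(-c4ccc(OC)cc4)n3)cc2F)ccn1` reaches only the limit of > 100000 nM in this assay, at which 1 of the 3 values shown sits, in this assay, so its value of > 100000 nM is a limit and not a number. How the core of compound 3 differs from the core of compound 2 is not broken down here. Among the measured compounds shown here, compound 4 `CNC(=O)c1cc(Oc2ccc(NC(=O)c3nccc(-c4ccc(OC)cc4)n3)cc2)ccn1` is not yet measured; it differs from compound 3 by hydrogen in place of fluoro on an aromatic carbon, the same change as the one between compound 2 and compound 1. For the measured compounds named here, the only reference for this change is the step of a 1.2-fold lower number from compound 2 to compound 1 (0.08 log units; within the scatter), which lies within the scatter. The step expected for compound 4 is a number no higher from compound 3 to compound 4 (the limit leaves the size open), as small as the one seen before. Compound 4 is thus estimated at 100000 nM, between 30000 nM and 300000 nM, with a high chance that only a limit is again reported.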

Compound 4, half-maximal inhibitory concentration: 35200 nM
Compound 4: the middle estimate sits 2.8-fold (0.45 log units) above what was measured; measured number inside the range.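

In this assay, hydrogen in place of fluoro on the core of compound 3 gives an at least 2.8-fold lower number from compound 3 to compound 4 (0.45 log units; beyond the scatter), a step whose size is open at one end. Compound 3 stands at > 100000 nM, which is a limit and not a number. This shows that the change can go with a step beyond the scatter on one core and within it on another, but it does not show that the two cores truly respond differently: the same change on two cores in this assay, a 1.2-fold lower number (0.08 log units; within the scatter) from compound 2 to compound 1 and an at least 2.8-fold lower number (0.45 log units; beyond the scatter) from compound 3 to compound 4; the limit leaves it open whether they differ

As far as these compounds go, it remains open whether chloro in place of fluoro on the same aromatic carbon would give a step readable on both cores. Also open, from the compounds shown here alone, is how either core would respond with an amine or a longer chain in place of the methoxy or ethyl group.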